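Working notes: compound 2 to compound 4

The source may hold more compounds than are shown below. What is called first, only, known or untested is meant among the compounds shown, and "the series" means these compounds.

In a functional assay on MDA-MB-436 cells (Homo sapiens) for antiproliferative activity, read by MTT assay, with a stated time of 24 h (on this read-out lower numbers stand for stronger inhibition and higher numbers for weaker inhibition), compound 2 (`O=C(O)CC(NC(=O)c1ccc(F)cc1)c1ccc(Cl)cc1Cl`) gives 55800 nM, and compound 3 (`O=C(O)CC(NC(=O)c1ccc(C(F)(F)F)cc1)c1ccc(Cl)cc1Cl`) gives 44100 nM. Among the measured compounds shown here, these are the only two numerical values so far, and they lie within the scatter of each other: a 1.3-fold lower number from compound 2 to compound 3 (0.10 log units; within the scatter). Compound 1 (`O=C(O)CC(NS(=O)(=O)c1ccc(F)cc1)c1ccccc1`) reads > 100000 nM, which is a limit of the assay and not a number.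

Compound 4 (`O=C(O)CC(NC(=O)c1c(Cl)cccc1Cl)c1ccc(Cl)cc1Cl`) keeps the acid side of compound 2 and changes the group on the carbonyl carbon: 2,6-dichlorophenyl in place of 4-fluorophenyl on a carbonyl carbon. In words, 2,6-dichlorophenyl comes in place of 4-fluorophenyl. For the measured compounds named here, only one measured step bears on this group, a 1.3-fold lower number from compound 2 to compound 3 (0.10 log units; within the scatter), and it replaces fluoro with trifluoromethyl on an aromatic carbon rather than exchanging the whole group. It is therefore weak guidance, but it gives no ground to expect a large move in this assay, and no step beyond the scatter is expected. The estimate is a 1.2-fold lower number from compound 2 to compound 4 (0.09 log units; within the scatter). Compound 4 is expected at 45000 nM, with an estimated range of 18000 nM to 100000 nM.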

Compound 4, half-maximal inhibitory concentration: > 100000 nM
Compound 4 ended at the assay's limit (the forecaster's own chance of this, stated with the estimate: 15%); middle value at least 2.2-fold (0.34 log units) away from the limit.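

In this assay, compound 4 gives > 100000 nM, which is a limit of the assay and not a number. Exchanging the whole group on the carbonyl carbon, with 2,6-dichlorophenyl in place of 4-fluorophenyl, gives an at least 1.7-fold higher number from compound 2 to compound 4 (0.25 log units; that floor lies within the scatter), so only a floor on the step is known, and the true size may lie within the scatter or well outside it. Unlike compound 2 and compound 3, which both give numbers, compound 4 leaves this position with no measured value, and the series has now reached its upper limit twice: the limit of > 100000 nM in this assay, at which 2 of the 4 values shown sit.

Compound 4 alone cannot separate the presence of the two chlorine atoms from the loss of the fluorine. Going by these compounds, it also remains open whether a phenyl group carrying an amine or a carboxylic acid, or a longer alkyl chain, at this position would give a number within the range of the assay.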